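Styryl sulfone analogues in a DU-145 growth assay

This account rests on a few compounds, and the source may have more. Where it says the series, first, only, none or still open, it means among the compounds named here.

Measured compounds:
- compound 1 `Cc1ccc(/C=C(\C(=O)c2ccc(Cl)cc2)S(=O)(=O)Cc2ccc(Cl)cc2Cl)s1`: 10000 nM
- compound 2 `Cc1ccc(S(=O)(=O)/C(=C/c2ccc(C)s2)C(=O)c2ccc(Cl)cc2)cc1`: 50000 nM
- compound 3 `Cc1ccc(CS(=O)(=O)/C(=C/c2ccc(C)s2)C(=O)c2ccc(Cl)cc2)cc1`: 25000 nM

In a functional assay on DU-145 cells (Homo sapiens) for inhibition, read by trypan blue exclusion, with a stated time of 96 h (a higher number here means a weaker inhibitor of growth, a lower number a stronger inhibitor of growth), compound 2 gives 50000 nM, the highest number of the three. Its nearest neighbour is compound 3, which gives 25000 nM in this assay, and the two lie within the scatter of each other; compound 1, which gives 10000 nM, is further off, with a 5.0-fold higher number from compound 1 to compound 2 (0.70 log units; beyond the scatter).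

Compound 4 `Cc1ccc(S(=O)(=O)/C(=C/c2ccc(O)c([N+](=O)[O-])c2)C(=O)c2ccc(Cl)cc2)cc1` has not yet been measured. It differs from compound 2 by 4-hydroxy-3-nitrophenyl in place of 5-methylthiophen-2-yl on a double-bonded chain carbon bound to a double-bonded chain carbon. All three measured steps change the group on the sulfonyl sulfur: a 5.0-fold higher number from compound 1 to compound 2 (0.70 log units; beyond the scatter), a 2.5-fold higher number from compound 1 to compound 3 (0.40 log units; beyond the scatter) and a 2.0-fold lower number from compound 2 to compound 3 (0.30 log units; within the scatter). Within the data shown here, none of them touches the double-bonded chain carbon where compound 4 differs, so no measured step bears directly on this change. Among the measured compounds shown here, with no precedent at that position, a step no larger than the modest ones seen elsewhere is expected, in either direction, and most likely none beyond the scatter. The step of a 1.7-fold lower number from compound 2 to compound 4 (0.22 log units; within the scatter) is therefore an estimate with wide uncertainty.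

Compound 4 is expected to give about 30000 nM in this assay, within a range from 8000 nM to 100000 nM.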

Compound 4, concentration for 50% growth inhibition: 25000 nM
Compound 4: the middle estimate sits 1.2-fold (0.08 log units) above what was measured; low and high end bracket the measured number.
By their numbers in this assay, from the lowest: compound 1; then compounds 3, 4 and 2 (each within the scatter of the next).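

The first change away from the sulfonyl sulfur shows that this position accepts a very different group: in this assay, 4-hydroxy-3-nitrophenyl in place of 5-methylthiophen-2-yl on the double-bonded chain carbon gives a 2.0-fold lower number from compound 2 to compound 4 (0.30 log units; within the scatter). The exchange is not a small one, since a carbon-only six-membered aromatic ring with 10 heavy atoms and a hydrogen-bond donor replaces a five-membered sulfur-containing aromatic ring with 6 heavy atoms and no donor, yet the two compounds cannot be told apart in this growth read-out. Nothing available accounts for this lack of separation.

The pair does not show what the hydroxy and nitro groups each contribute, or whether an amine in place of the nitro group or a carboxylic acid on the same ring would also leave the number within the scatter. Going by these compounds, it also rests on a single group on the sulfonyl sulfur, the 4-methylphenyl, so whether the same exchange would hold with the 2,4-dichlorobenzyl group of compound 1 remains open.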